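From Bromo to Hydrogen: Expecting Only Scatter-Sized Movement

The source may report more compounds than this note shows. Statements on the series, on what has been measured and on what is new or still open speak of the compounds shown alone.

Measured compounds:
compound 1 `N#CC1=C(N)OC(c2c[nH]c3ccccc23)=C(C#N)C1c1ccc(Br)cc1`: 14.2%
compound 2 `COc1ccc(C2C(C#N)=C(N)OC(c3c[nH]c4ccccc34)=C2C#N)cc1`: 12.4%
compound 3 `N#CC1=C(N)OC(c2c[nH]c3ccccc23)=C(C#N)C1c1ccc(F)cc1`: 8.4%

All three compounds share one core and differ only in the group sitting on one aromatic carbon of the six-membered aromatic ring of carbon only. In a functional assay, tested at 50 ug/mL (on this read-out lower numbers stand for a weaker effect and higher numbers for a stronger effect at the one concentration tested), compound 1 gives the largest of the three numbers, yet this means little: the step of a number 1.8 percentage points lower from compound 1 to compound 2 (within the scatter) and the step of a number 5.8 percentage points lower from compound 1 to compound 3 (within the scatter) both lie within the scatter, so the three compounds cannot be told apart on these numbers.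

Compound 4 `N#CC1=C(N)OC(c2c[nH]c3ccccc23)=C(C#N)C1c1ccccc1` is not yet measured. Its difference from compound 1 is hydrogen in place of bromo on an aromatic carbon. The three measured steps bear on it directly, since each of them is also an exchange at the same aromatic carbon: methoxy in place of bromo, fluoro in place of bromo, and fluoro in place of methoxy, the last being a number 4 percentage points lower from compound 2 to compound 3 (within the scatter). None of them moved the read-out beyond the scatter. Replacing bromo by hydrogen is therefore expected to behave the same way, with no step beyond the scatter in either direction.

The expected step is a number 3.2 percentage points lower from compound 1 to compound 4 (within the scatter). Compound 4 is estimated to give 11% in this assay, with a range from 3% to 20%.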

Compound 4, a percentage reported as activity, at one concentration (the size of the read-out at that concentration, not a potency): 14.4%
For compound 4 the middle estimate is 3.4 percentage points below the measured one; the range from low to high includes it.
By their numbers in this assay, from the lowest: compounds 3, 2, 1 and 4 (each within the scatter of the next).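

Compound 4 shows that this aromatic carbon does not need a group other than hydrogen to keep the read-out where it was: in this assay the change from 4-bromophenyl to phenyl gives a number 0.2 percentage points higher from compound 1 to compound 4 (within the scatter) and so the two compounds cannot be told apart. The earlier compounds shown here only swapped one group for another, whereas here the group is removed altogether, and the comparisons with the other two groups agree, with a number 6 percentage points higher from compound 3 to compound 4 (within the scatter) and a number 2 percentage points higher from compound 2 to compound 4 (within the scatter) as the remaining steps. Across bromo, methoxy, fluoro and hydrogen, then, the group at this carbon makes no readable difference at the one concentration tested, and that holds for these four compounds only.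

On these data alone, whether a different kind of group at this carbon, such as an amine, a carboxylic acid or a longer alkyl chain, would move the read-out beyond the scatter remains open, as does the effect of changes elsewhere on the shared core. Nothing available explains why these four numbers sit so close together.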